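The source may report more compounds than this note shows. Statements on the series, on what has been measured and on what is new or still open speak of the compounds shown alone.

Working notes on the series. Compound 1 `CCCCCCCCc1ccc(CCC(N)(CO)C(=O)O)cc1` carries a carboxy and a hydroxymethyl on the carbon that bears the amine nitrogen. In a functional assay on the whole organism (spleen, spleen) with Rattus norvegicus as the target (a lower number here means that less compound is needed, a higher number that more compound is needed for the effect), compound 1 gives > 10 mg/kg, which is a limit of the assay and not a number. Compound 2 `CCCCCCCCc1ccc(CCC(N)CO)cc1` has hydrogen in place of carboxy on a saturated chain carbon bound to an amine nitrogen and two saturated chain carbons. In this assay compound 2 gives > 10 mg/kg, again a limit rather than a number. The step that the two limits leave unreadable from compound 1 to compound 2 therefore cannot be sized. Within the data shown here, compound 3 `C=CCC(N)(CO)CCc1ccc(OCCCCCCC)cc1` is the only member with a measured number: in this assay compound 3 gives 1.9 mg/kg, while the other two values sit at the limit of > 10 mg/kg in this assay, at which 2 of the 3 values shown sit.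

Compound 4 `CCCCCCCOc1ccc(CCC(N)(CO)CCCC)cc1` differs from compound 3 by propyl in place of vinyl on a saturated chain carbon, two bonds along the chain from an amine nitrogen. Among the measured compounds shown here, no measured step touches this position, and the single readable step is unreadable in size, so no measured step bears on the change. The change swaps one small hydrocarbon chain for another at the same carbon, and no movement beyond the usual scatter is expected; the step of a 1.1-fold higher number from compound 3 to compound 4 (0.02 log units; within the scatter) is expected to stay within it. For compound 4 the estimate in this assay is 2 mg/kg, with a range from 0.8 mg/kg to 5 mg/kg.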

Compound 4, dose for 50% inhibition: > 10 mg/kg
Compound 4 gave a limit, no number (the forecaster's own chance of this, stated with the estimate: 15%); at least 5.0-fold (0.69 log units) between middle value and limit.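

In this assay, propyl in place of vinyl on a saturated chain carbon, two bonds along the chain from an amine nitrogen, gives an at least 5.2-fold higher number from compound 3 to compound 4 (0.72 log units; beyond the scatter). Among these compounds, this is the first readable step, and it shows that these two small hydrocarbon chains are not interchangeable at this position, a point that the earlier compounds, with no readable step among them, could not show. Compound 4 gives > 10 mg/kg, which is a limit of the assay and not a number, so compound 3 remains the only member with a number and the others share one limit: the limit of > 10 mg/kg in this assay, at which 3 of the 4 values shown sit.

Read one bond further out, the same change is allyl to butyl; it removes the double bond and adds to the carbon count together, and the compounds shown do not separate the two. Open at this position are a propyl or a propargyl group in place of the allyl of compound 3, and how far the number of compound 4 actually lies from that of compound 3.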